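Moving chlorine from 2-chlorobenzyl to 3-chlorobenzyl in compound 2

A few compounds are considered here, and "the series" means these few. Any claim that something is new, unique, unknown or untested is made for them only; others in the source may bear on it.

- Compound 1 `O=C(Nc1ccc(C(F)(F)F)cc1)Nc1cc2ncncc2cc1OCc1cccc(F)c1` gives 3200 nM
- Compound 2 `O=C(Nc1cccc(F)c1)Nc1cc2ncncc2cc1OCc1ccccc1Cl` gives 3200 nM

Both values come from a functional assay on GBM2 cells (Homo sapiens) for antiproliferative activity, read by WST assay, with a stated time of 72 h (a higher number here means a weaker inhibitor, a lower number a stronger inhibitor), and stand level, with no difference between them at the digits reported. Compound 2 therefore has no measured advantage over compound 1, and the two remain within the usual scatter of repeated measurements.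

Compound 3 `O=C(Nc1cccc(F)c1)Nc1cc2ncncc2cc1OCc1cccc(Cl)c1` keeps everything in compound 2 except one group. It carries 3-chlorophenyl in place of 2-chlorophenyl on a saturated chain carbon bound to an oxygen on an aromatic ring. In other words, 2-chlorobenzyl becomes 3-chlorobenzyl.

Among the compounds with values here, no measured pair differs at this place alone, so the data offer no direct guide to the size or direction of the step. Compound 1 (3200 nM) differs from compound 2 in more than one place, yet the two values are level. On that slender basis, no change beyond the scatter is expected in this assay.

The expected outcome is an estimated 1.3-fold lower number from compound 2 to compound 3 (0.11 log units; within the scatter) and no clear shift in either direction.

Compound 3 is estimated at 2500 nM (expected range 800 nM to 7000 nM).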

Compound 3, half-maximal inhibitory concentration: 7800 nM
Compound 3: middle estimate off by 3.1-fold (0.49 log units), on the low side, outside the stated range (above it).
By their numbers in this assay, from the lowest: compounds 1 and 2 (each within the scatter of the next); then compound 3.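

In this assay the change from 2-chlorobenzyl to 3-chlorobenzyl gives a 2.4-fold higher number from compound 2 to compound 3 (0.39 log units; beyond the scatter), the only comparison among these compounds in which a single place differs. It shows that this place, on a saturated chain carbon bound to an oxygen on an aromatic ring, is not indifferent to how the group is built: 2-chlorophenyl and 3-chlorophenyl have the same atoms and the same counts, yet the change in the number lies beyond the scatter, and in the direction of a weaker inhibitor. No measurement among those shown accounts for this step, which remains a single observation on one pair.

The compounds shown leave open whether chlorine is of any benefit here at all, since a plain benzyl group, which would set both chlorinated compounds against a common reference, is not among them, and neither is a longer chain such as phenethyl. They also leave open whether this step would keep its size and direction if another part of the molecule were different, as a single pair cannot tell.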